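Swapping Chloro for Methyl in a Flat Series

The source may hold more compounds than are shown below. What is called first, only, known or untested is meant among the compounds shown, and "the series" means these compounds.

In a functional assay on HeLa cells (Homo sapiens) for antiproliferative activity, read by MTT assay, with a stated time of 72 h (on this read-out higher numbers stand for weaker inhibition and lower numbers for stronger inhibition), compound 3 `CCn1cc(C(=O)O)c(=O)c2cc(F)c(N3CCN(C(=N)NS(=O)(=O)c4ccc(Cl)cc4)CC3)cc21` gives 32 nM, level with compound 1 `CCn1cc(C(=O)O)c(=O)c2cc(F)c(N3CCN(C(=N)NS(=O)(=O)c4ccccc4Cl)CC3)cc21` at 32 nM and compound 2 `CCn1cc(C(=O)O)c(=O)c2cc(F)c(N3CCN(C(=N)NS(=O)(=O)c4ccccc4)CC3)cc21` at 32 nM. Compound 4 `CCn1cc(C(=O)O)c(=O)c2cc(F)c(N3CCN(C(=N)NS(=O)(=O)c4ccc(C)cc4)CC3)cc21` has methyl in place of chloro on an aromatic carbon, para to a large group (methyl in place of chloro on an aromatic carbon). For the measured compounds named here, three measured steps bear on this change. Chloro in place of hydrogen gave no change at the digits printed from compound 2 to compound 3 (within the scatter), 4-chlorophenyl in place of 2-chlorophenyl gave no change at the digits printed from compound 1 to compound 3 (within the scatter), and hydrogen in place of chloro gave no change at the digits printed from compound 1 to compound 2 (within the scatter). Going by the values given here, no methyl compound has a measured value yet, but with all three steps inside the scatter, no shift beyond it is expected in this assay. The expected step is no change at the digits printed from compound 3 to compound 4 (within the scatter). Compound 4 is estimated at 32 nM, with an expected range of 15 nM to 70 nM.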

Compound 4, half-maximal inhibitory concentration: 32 nM
The estimate for compound 4 equals the measured number at the digits printed; measured number inside the range.
By their numbers in this assay, from the lowest: compounds 1, 2, 3 and 4 (each within the scatter of the next).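

In this assay methyl joins chloro and hydrogen at this place on the aromatic ring, with no change at the digits printed from compound 3 to compound 4 (within the scatter) on replacing chloro and no change at the digits printed from compound 2 to compound 4 (within the scatter) on replacing hydrogen. Set against the 2-chlorophenyl group, 4-methylphenyl also shows no change at the digits printed from compound 1 to compound 4 (within the scatter) in this comparison. No measurement at hand offers a reason for this flat result.

From the compounds shown here alone, whether an amine, a carboxylic acid or a longer chain such as butyl at this place would move the number remains open. So does whether this flat result holds in other cell lines.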